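Thiophene for Furan on Two Related Nucleoside Cores

This account rests on a few compounds, and the source may have more. Where it says the series, first, only, none or still open, it means among the compounds named here.

Measured so far in a functional assay on CEM-DNR-bulk cells (Homo sapiens), read by MTT assay, with a stated time of 72 h; a lower number here means a stronger inhibitor, a higher number a weaker inhibitor:
Compound 1, `Cc1nc(N)c2c(-c3cccs3)cn([C@@H]3O[C@H](CO)[C@@H](O)[C@H]3O)c2n1`, gives > 20000 nM.
Compound 2, `CSc1ncnc2c1c(-c1ccoc1)cn2[C@@H]1O[C@H](CO)[C@@H](O)[C@H]1O`, gives > 20000 nM.
Compound 3, `Cc1nc(N)c2c(-c3ccoc3)cn([C@@H]3O[C@H](CO)[C@@H](O)[C@H]3O)c2n1`, gives > 20000 nM.

Each of these three values is a limit of this assay rather than a number. For compound 1 the value is a limit. For compound 2 the value is likewise a limit. For compound 3 the value is a limit as well. All three sit at the same point, namely (the limit of > 20000 nM in this assay, at which 3 of the 3 values shown sit).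

Compound 3 and compound 1 share a core and differ only by the change (thiophen-2-yl in place of furan-3-yl on an aromatic carbon). The step that this change made, a step that the two limits leave unreadable from compound 3 to compound 1, cannot be read in size, since both ends of it are limits. The difference between the core of compound 2 and the core of compound 3 is not broken down here.

Compound 4, `CSc1ncnc2c1c(-c1cccs1)cn2[C@@H]1O[C@H](CO)[C@@H](O)[C@H]1O`, has not yet been measured. It stands to compound 2 as compound 1 stands to compound 3: the change is thiophen-2-yl in place of furan-3-yl on an aromatic carbon, and its place line matches that of the earlier change word for word, so it is the same change made on a second core.

The expectation for compound 4 rests on compound 2, whose value in this assay is a limit, and on the earlier step that the two limits leave unreadable from compound 3 to compound 1, which showed no readable movement. Compound 4 is therefore expected to remain at or near the limit, with an estimated step that the limit leaves unreadable from compound 2 to compound 4. The estimate for compound 4 in this assay is 30000 nM, expected to lie between 12000 nM and 80000 nM.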

Compound 4, half-maximal inhibitory concentration: > 20000 nM
Compound 4 ended at the assay's limit (the forecaster's own chance of this, stated with the estimate: 85%); the middle value lies beyond the limit too.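

In this assay compound 4 gives > 20000 nM and that value is a limit of the assay, not a number. Compound 2 also stands at a limit, so the size of the change from compound 2 to compound 4 cannot be read. The compounds shown leave open whether thiophen-2-yl in place of furan-3-yl shifts potency on either core, as all of them sit at one point: the limit of > 20000 nM in this assay, at which 4 of the 4 values shown sit.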